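Swapping the Aryl Group on a Thiourea Core

The compounds below may be only part of what the source reports. "The series", "measured", "known", "first", "only" and "open" are said of these compounds alone.

Measured compounds:
Compound 1 `COc1cc(/C=C/C(=O)C2=C(/C=C/c3ccc(O)c(OC)c3)NC(=O)NC2c2ccccc2O)ccc1O` — 100000 nM
Compound 2 `COc1cc(/C=C/C(=O)C2=C(/C=C/c3ccc(O)c(OC)c3)NC(=O)NC2c2ccc(N(C)C)cc2)ccc1O` — 12500 nM
Compound 3 `COc1cc(/C=C/C(=O)C2=C(/C=C/c3ccc(O)c(OC)c3)NC(=S)NC2c2ccccc2O)ccc1O` — 100000 nM

In a functional assay on HCT-116 cells (Homo sapiens) for cytotoxicity, read by MTT assay, with a stated time of 48 h (a lower number here means a stronger inhibitor, a higher number a weaker inhibitor), compound 1 gives 100000 nM. Compound 2 differs from compound 1 in one place: 4-(dimethylamino)phenyl in place of 2-hydroxyphenyl on a saturated ring carbon. This change gives an 8.0-fold lower number from compound 1 to compound 2 (0.90 log units; beyond the scatter), a modest but real gain. Compound 3 carries a different core; how the two cores differ is not broken down here. In this assay compound 3 gives 100000 nM, level with compound 1 at the digits shown.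

Compound 4 `COc1cc(/C=C/C(=O)C2=C(/C=C/c3ccc(O)c(OC)c3)NC(=S)NC2c2ccc(N(C)C)cc2)ccc1O` has not yet been measured. It differs from compound 3 as 4-(dimethylamino)phenyl in place of 2-hydroxyphenyl on a saturated ring carbon, the same change, at the same place, that turned compound 1 into compound 2. Because that change gave an 8.0-fold lower number from compound 1 to compound 2 (0.90 log units; beyond the scatter), a step of similar size is expected here, namely an 8.0-fold lower number from compound 3 to compound 4 (0.90 log units; beyond the scatter). On that basis compound 4 is estimated at 12500 nM in this assay, most likely between 4000 nM and 50000 nM.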

Compound 4, half-maximal inhibitory concentration: 12500 nM
Estimate against measurement, compound 4: no gap at the digits printed, and the stated range covers the measured number.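

In this assay, placing 4-(dimethylamino)phenyl where 2-hydroxyphenyl stood on the saturated ring carbon gives an 8.0-fold lower number from compound 3 to compound 4 (0.90 log units; beyond the scatter), so the gain seen on the core of compound 1 also appears on the core of compound 3. Set side by side, the two steps agree: the same change on two cores in this assay, an 8.0-fold lower number (0.90 log units; beyond the scatter) from compound 1 to compound 2 and an 8.0-fold lower number (0.90 log units; beyond the scatter) from compound 3 to compound 4, 1.0-fold (0.00 log units) apart, within the scatter of two such steps. Within the data shown here, this shows that the change carried over between these two cores in this one cell assay, but with only two pairs it does not show that the step would hold on any other core.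

Among these compounds, with only two aryl groups compared at this place, it remains open whether a plain phenyl, a 4-methoxyphenyl or a 4-aminophenyl would give a similar step on both cores. Also open, as far as these compounds go, is whether the step would survive if a carboxylic acid replaced the hydroxyl on the 2-(4-hydroxy-3-methoxyphenyl)ethenyl group.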